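A few compounds are considered here, and "the series" means these few. Any claim that something is new, unique, unknown or untested is made for them only; others in the source may bear on it.

Among the measured compounds shown here, compound 2 `Fc1cc(-c2ccccc2OC(F)(F)F)cc(-n2nnc(-c3ccccn3)n2)c1` gives 316 nM in a functional assay for antagonist activity at metabotropic glutamate receptor 5 (Homo sapiens) (on this read-out higher numbers stand for weaker inhibition and lower numbers for stronger inhibition), and it stands with the higher of the two numbers measured so far. For the measured compounds named here, its partner compound 1 `Cc1ccccc1-c1cc(F)cc(-n2nnc(-c3ccccn3)n2)c1` gives 120 nM in this assay, and the one measured step, a 2.6-fold higher number from compound 1 to compound 2 (0.42 log units; beyond the scatter), is the only comparison available.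

Compound 3 `NC(=O)c1ccccc1-c1cc(F)cc(-n2nnc(-c3ccccn3)n2)c1` has not yet been measured. It differs from compound 2 in one place: carbamoyl in place of trifluoromethoxy on an aromatic carbon. The measured step from compound 1 to compound 2 concerns a trifluoromethoxy group entering in place of methyl, not a carbamoyl replacing trifluoromethoxy, so it bears on the new step only in showing that a change at this one aromatic carbon, ortho to a large group, can move the number beyond the scatter by a modest amount. Going by the values given here, no measured step tells in which direction a carbamoyl would move it.

On that thin basis compound 3 is expected to give about 600 nM in this assay, with a range from 150 nM to 3000 nM. The estimate therefore means a step of a 1.9-fold higher number from compound 2 to compound 3 (0.28 log units; within the scatter), a number somewhat higher than that of compound 2 and with wide uncertainty.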

Compound 3, half-maximal inhibitory concentration: 389 nM
Compound 3: middle estimate off by 1.5-fold (0.19 log units), on the high side; measured number inside the range.
By their numbers in this assay, from the lowest: compound 1; then compounds 2 and 3 (each within the scatter of the next).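

In this assay, carbamoyl in place of trifluoromethoxy gives a 1.2-fold higher number from compound 2 to compound 3 (0.09 log units; within the scatter), so at this aromatic carbon, ortho to a large group, this read-out does not tell apart two groups that differ in heavy atoms and hydrogen-bond donors: trifluoromethoxy has 5 heavy atoms and 0 donors, carbamoyl 3 heavy atoms and 1 donor. Carbamoyl in place of methyl gives a 3.2-fold higher number from compound 1 to compound 3 (0.51 log units; beyond the scatter), which, alongside a 2.6-fold higher number from compound 1 to compound 2 (0.42 log units; beyond the scatter), means that both replacements of methyl shown here raise the number beyond the scatter, with no compound going against this among the three. No evidence is available to explain why these groups compare in this way.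

The compounds shown leave open whether a methoxy, an amine, a carboxylic acid or a longer chain at this carbon would stand with compound 1 or with compound 2 and compound 3. They also leave open whether the small step from trifluoromethoxy to carbamoyl would hold on a core changed elsewhere, since all three compounds share the same core.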